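Dropping the Fluoro: From Compound 1 to Compound 3

This account rests on a few compounds, and the source may have more. Where it says the series, first, only, none or still open, it means among the compounds named here.

Compound 1, `Fc1ccc(-c2csc(N/N=C/c3ccc(Cl)cc3Cl)n2)cc1`: 90%
Compound 2, `COC(=O)c1cc(-c2csc(N/N=C/c3ccc(Cl)cc3Cl)n2)ccc1OCc1ccccc1`: 63.5%

In a functional assay, read by spectrophotometry, with a stated time of 15 min, tested at 40 ug/mL (on this read-out lower numbers stand for a weaker effect and higher numbers for a stronger effect at the one concentration tested), compound 1 gives 90%, the highest of the two numbers measured. Compound 2 gives 63.5%, a number that sits beyond the scatter below compound 1. Compound 3, `Clc1ccc(/C=N/Nc2nc(-c3ccccc3)cs2)c(Cl)c1`, has not yet been measured; it differs from compound 1 by hydrogen in place of fluoro on an aromatic carbon. For the measured compounds named here, no pair of measured compounds shows what this change does on its own. A single hydrogen entering for fluoro is a small change, so a step within the scatter is expected, leaning downward if anywhere: a number 8 percentage points lower from compound 1 to compound 3 (within the scatter). Compound 3 is therefore expected to give 82%, with a range from 65% to 95%.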

Compound 3, a percentage reported as inhibition, at one concentration (the size of the read-out at that concentration, not a potency): 78.9%
Compound 3: middle estimate off by 3.1 percentage points, on the high side; low and high end bracket the measured number.
By their numbers in this assay, from the lowest: compound 2; then compound 3; then compound 1.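

Swapping 4-fluorophenyl for phenyl gives a number 11.1 percentage points lower from compound 1 to compound 3 (beyond the scatter) in this assay, the first reading of this single change on its own. Losing the fluoro thus moves the number beyond the scatter, yet compound 3 still gives 78.9% at the one concentration tested, so the fluoro is not essential for a strong read-out. Nothing measured here explains why the number moves. As far as these compounds go, whether a methoxy group or an amine on this aromatic carbon would match fluoro or hydrogen stays open. So does whether this step would be the same on the more heavily substituted ring of compound 2.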